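The source may report more compounds than this note shows. Statements on the series, on what has been measured and on what is new or still open speak of the compounds shown alone.

In a functional assay on MCF7 cells (Homo sapiens) for inhibition, read by MTT assay, with a stated time of 3 days (on this read-out higher numbers stand for weaker inhibition and lower numbers for stronger inhibition), compound 1 `COc1ccc(/C=C\c2cc(OC)c(OC)c(OC)c2)cc1OCc1ccccc1` gives 59000 nM, and compound 2 `COc1ccc(/C=C\c2cc(OC)c(OC)c(OC)c2)cc1OCCC/C=C/c1ccc(Cl)cc1` gives 40000 nM, so compound 2 cannot be told apart from compound 1. Compound 3 `COc1ccc(/C=C\c2cc(OC)c(OC)c(OC)c2)cc1OCCC/C=C/c1ccc(Br)cc1` differs from compound 2 by bromo in place of chloro on an aromatic carbon, which puts bromo in place of chloro on an aromatic carbon. Among the measured compounds shown here, the only measured guide is a 1.5-fold lower number from compound 1 to compound 2 (0.17 log units; within the scatter), and that came from a much larger change to the group on the oxygen. A far smaller swap is therefore expected to leave no step beyond the scatter in this assay, and the expected step is a 1.1-fold lower number from compound 2 to compound 3 (0.02 log units; within the scatter). Compound 3 is estimated at 38000 nM, with an expected range of 15000 nM to 90000 nM.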

Compound 3, half-maximal inhibitory concentration: 37000 nM
For compound 3 the middle estimate is 1.0-fold (0.01 log units) above the measured one; low and high end bracket the measured number.
By their numbers in this assay, from the lowest: compounds 3, 2 and 1 (each within the scatter of the next).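

In this assay, bromo in place of chloro on the aromatic carbon gives a 1.1-fold lower number from compound 2 to compound 3 (0.03 log units; within the scatter) and so cannot be told apart from chloro at this position, para to a large group. The bromo compound also stays close to the simpler phenyl group, with a 1.6-fold lower number from compound 1 to compound 3 (0.20 log units; within the scatter) across the larger change on the oxygen. Nothing given here explains these results.

The compounds shown leave open whether a group of another kind on this aromatic carbon, such as an amine or a carboxylic acid, would move the number beyond the scatter. From the compounds shown here alone, a shorter or longer chain between the oxygen and the 4-bromophenyl group also remains untested here.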